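Methylthio series: removing the methoxy from the benzyl group

The compounds below may be only part of what the source reports. "The series", "measured", "known", "first", "only" and "open" are said of these compounds alone.

Measured so far:
compound 1 `[SeH]c1nc(NCc2ccccc2)c2cccnc2n1` — 30 nM
compound 2 `COc1ccc(CNc2nc(SC)nc3ncccc23)cc1` — 48100 nM

Compound 2 holds the higher of the two numbers in a functional assay on MCF7 cells (Homo sapiens) for cytotoxicity, read by MTT assay, with a stated time of 72 h; a lower number here means a stronger inhibitor of growth, a higher number a weaker inhibitor of growth; compound 1 sits far lower, by a gap well beyond the scatter. Going by the values given here, compound 1 and compound 2 differ in more than one place, so no single step between them is computed, and the two values alone cannot say how much of the gap goes with the methoxy.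

Compound 3 `CSc1nc(NCc2ccccc2)c2cccnc2n1` takes compound 2 and changes one thing: hydrogen in place of methoxy on an aromatic carbon. Among the compounds with values here, no measured pair shows this change on its own, so its size here is unknown. A modest downward step, or none beyond the scatter, is expected in this assay.

Compound 3 is expected at 20000 nM, between 3000 nM and 60000 nM. That estimate means an expected step of a 2.4-fold lower number from compound 2 to compound 3 (0.38 log units; beyond the scatter).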

Compound 3, concentration for 50% growth inhibition: 39400 nM
Compound 3: the middle estimate sits 2.0-fold (0.29 log units) below what was measured; low and high end bracket the measured number.
By their numbers in this assay, from the lowest: compound 1; then compounds 3 and 2 (each within the scatter of the next).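

In this assay hydrogen in place of methoxy, on an aromatic carbon para to a large group, gives a 1.2-fold lower number from compound 2 to compound 3 (0.09 log units; within the scatter) and so leaves no readable effect of the methoxy in the methylthio series. With the benzyl group now the same on both sides, the large gap can be tied to a single change: a group of 2 heavy atoms (1 carbon, 1 sulfur) in place of one selenium atom gives a 1300-fold higher number from compound 1 to compound 3 (3.12 log units; beyond the scatter) on the shared core. Nothing available gives a reason for either step.

From the compounds shown here alone, whether methoxy is equally silent with the selenium atom in place remains open, as does the outcome for an amine or a carboxylic acid on the same aromatic carbon. Going by these compounds, how a longer chain on the sulfur, or an oxygen atom in place of the selenium atom, would read also remains open.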